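Swapping phenyl for an azetidinyl-pyridinyl group in a thiazole acid

This account rests on a few compounds, and the source may have more. Where it says the series, first, only, none or still open, it means among the compounds named here.

Compound 3 `O=C(O)Cc1sc(C(c2ccc(F)cc2)c2ccc(F)cc2)nc1-c1ccccc1` reaches 80% in an in vitro functional assay on HEK285-7 cells for antagonist activity at prostaglandin D2 receptor 2 (Homo sapiens), read by BRET and beta-arrestin recruitment; a higher number here means a larger maximal response, a lower number a smaller maximal response. Compound 2 `O=C(O)Cc1sc(C(c2ccc(F)cc2)c2ccc(F)cc2)nc1-c1ccc(Cl)cc1` gives 80%, and compound 1 `COc1cc(-c2nc(C(c3ccc(F)cc3)c3ccc(F)cc3)sc2CC(=O)O)ccn1` gives 60%. Compound 3 thus stands level with compound 2, the two together at the top of the three numbers, with no change at the digits printed from compound 2 to compound 3 (within the scatter), while a number 20 percentage points higher from compound 1 to compound 3 (beyond the scatter). Compound 4 `O=C(O)Cc1sc(C(c2ccc(F)cc2)c2ccc(F)cc2)nc1-c1ccnc(N2CCC2)c1` differs from compound 3 in one place: 2-(azetidin-1-yl)pyridin-4-yl in place of phenyl on an aromatic carbon. Within the data shown here, the step that bears on this is the one from compound 1 to compound 3, where a ring with one nitrogen gave way to phenyl and the maximal response rose by a modest amount; compound 4 reverses that kind of change. A modest drop is therefore expected, a number 20 percentage points lower from compound 3 to compound 4 (beyond the scatter). Compound 4 is estimated at 60%, between 45% and 80%.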

Compound 4, largest response reached (reported as efficacy), in percent of the reference or control that the assay uses: 80%
Estimate against measurement, compound 4: 20 percentage points below, and the stated range covers the measured number.
By their numbers in this assay, from the lowest: compound 1; then compounds 2, 3 and 4 (each within the scatter of the next).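

In this assay, 2-(azetidin-1-yl)pyridin-4-yl is accepted at this position, with no change at the digits printed from compound 3 to compound 4 (within the scatter) and no change at the digits printed from compound 2 to compound 4 (within the scatter). A pyridine ring here therefore does not always go with the lower number, since azetidin-1-yl in place of methoxy gives a number 20 percentage points higher from compound 1 to compound 4 (beyond the scatter). Nothing measured here explains why the azetidin-1-yl and methoxy groups differ.

From the compounds shown here alone, it remains open whether another amine on the pyridine ring, such as pyrrolidin-1-yl or dimethylamino, would match compound 4 or sit with compound 1.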